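The compounds below may be only part of what the source reports. "The series", "measured", "known", "first", "only" and "open" are said of these compounds alone.

compound 1 `COc1ncc(-c2ccc3nc(NC(=O)NCCN4CCCCC4)nn3c2)cc1NS(=O)(=O)c1ccc(F)cc1` gives 1080 nM
compound 2 `CCN(CC)CCNC(=O)Nc1nc2ccc(-c3cnc(OC)c(NS(=O)(=O)c4ccc(F)cc4F)c3)cn2n1` gives 1060 nM
compound 3 `CCN(CC)CCNC(=O)Nc1nc2ccc(-c3cnc(OC)c(NS(=O)(=O)c4ccc(Cl)cc4)c3)cn2n1` gives 760 nM

These values come from a functional assay on U-87MG ATCC cells for cytotoxicity against U-87 MG (Homo sapiens), read by MTT assay, with a stated time of 72 h (on this read-out lower numbers stand for stronger inhibition and higher numbers for weaker inhibition), and lie within the scatter of one another, so compound 1 at 1080 nM is not separated from the other two.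

Compound 4 `CNC(=O)Nc1nc2ccc(-c3cnc(OC)c(NS(=O)(=O)c4ccc(F)cc4)c3)cn2n1` is still unmeasured. It differs from compound 1 by one change: hydrogen in place of (piperidin-1-yl)methyl on a saturated chain carbon bound to an amide-type nitrogen. In words, this is hydrogen in place of (piperidin-1-yl)methyl on a saturated chain carbon bound to an amide-type nitrogen, so that 2-(piperidin-1-yl)ethyl becomes methyl.

Among the compounds with values here, the only measured step, a 1.4-fold lower number from compound 2 to compound 3 (0.14 log units; within the scatter), stays within the scatter and concerns a group on a sulfonyl sulfur, not this chain. Within the data shown here, no measured pair varies the chain alone, so the data give neither a size nor a direction for this change. Going by these compounds, a small shift is assumed, and a move either way remains open.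

The expected step is a 1.4-fold lower number from compound 1 to compound 4 (0.13 log units; within the scatter), with its direction uncertain. For compound 4 the estimated value is 800 nM, with an expected range from 150 nM to 4000 nM.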

Compound 4, half-maximal inhibitory concentration: 640 nM
Compound 4: middle estimate off by 1.3-fold (0.10 log units), on the high side, and the stated range covers the measured number.
By their numbers in this assay, from the lowest: compounds 4, 3, 2 and 1 (each within the scatter of the next).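

In this assay, the pair of compound 1 and compound 4 is the only one shown that varies this chain alone: methyl in place of 2-(piperidin-1-yl)ethyl gives a 1.7-fold lower number from compound 1 to compound 4 (0.23 log units; within the scatter). The step removes the whole (piperidin-1-yl)methyl group, ring included, yet the two compounds are not separated, so in this cell read-out the series does not depend on that group at this place. Nothing available bears on why the two compounds read alike.

Still open, going by these compounds, is whether a group of another kind at this place, such as a carboxylic acid, a primary amine or a longer chain ending in a morpholine ring, would move the number beyond the scatter. Also open, on these data alone, is whether the same chain change would read alike with 4-chlorophenyl or 2,4-difluorophenyl on the sulfonyl sulfur.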